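The source may report more compounds than this note shows. Statements on the series, on what has been measured and on what is new or still open speak of the compounds shown alone.

Working notes on the series.

Compound 3 `Cc1nn(-c2ncnc3nc[nH]c23)c2c1C(OCc1ccc(C(C)C)cc1)CC(=O)N2` gives 5 nM in a functional assay on HEK293 cells for agonist activity at G-protein coupled receptor 39 (Homo sapiens), read by scintillation proximity assay and inositol phosphate accumulation, with a stated time of 75 min, in the presence of a further agent that is not named here; a higher number here means that more compound is needed for the effect, a lower number that less compound is needed. The shared core of compound 1 `Cc1nn(-c2ncnc3nc[nH]c23)c2c1C(OC1CCCC1)CC(=O)N2` gives 2 nM in this assay, and compound 2 `Cc1nn(-c2ncnc3nc[nH]c23)c2c1C(C(=O)Nc1ccccc1)CC(=O)N2` gives 10 nM. Compound 3 is separated from compound 1 by a 2.5-fold higher number from compound 1 to compound 3 (0.40 log units; beyond the scatter), while its number and that of compound 2 lie within the scatter of each other. The two measured steps, a 5.0-fold higher number from compound 1 to compound 2 (0.70 log units; beyond the scatter) and a 2.5-fold higher number from compound 1 to compound 3 (0.40 log units; beyond the scatter), both concern what is carried on the saturated carbon of the core; neither alters a substituent on the benzyl ring.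

Compound 4 `Cc1nn(-c2ncnc3nc[nH]c23)c2c1C(OCc1ccc(C#N)cc1)CC(=O)N2` differs from compound 3 by cyano in place of isopropyl on an aromatic carbon. Among the measured compounds shown here, no measured step in this assay touches this position, so the only guidance is that exchanges on this side of the core have so far moved the number by modest amounts. A step of about the size of the measured ones, or none beyond the scatter, is expected for compound 4: the number in this assay is estimated at 7 nM, within 2.5 nM to 20 nM, which is an expected step of a 1.4-fold higher number from compound 3 to compound 4 (0.15 log units; within the scatter).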

Compound 4, half-maximal effective concentration: 4 nM
Compound 4: middle estimate off by 1.8-fold (0.24 log units), on the high side; measured number inside the range.
By their numbers in this assay, from the lowest: compounds 1, 4, 3 and 2 (each within the scatter of the next, the first and the last beyond it).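

Among the compounds shown here, on the benzyl ring, in this assay, the change from 4-isopropylbenzyl to 4-cyanobenzyl gives a 1.3-fold lower number from compound 3 to compound 4 (0.10 log units; within the scatter), the only measured exchange at this position, and it stays within the scatter despite the change from isopropyl to cyano. Set against the other groups on the saturated carbon of the core, 4-cyanobenzyl gives a 2.0-fold higher number from compound 1 to compound 4 (0.30 log units; within the scatter), again within the scatter, whereas (4-cyanobenzyl)oxy in place of phenylcarbamoyl gives a 2.5-fold lower number from compound 2 to compound 4 (0.40 log units; beyond the scatter), which lies beyond it. No measured property of these groups is available to account for this result.

Open, on these data alone, is whether an amine, a carboxylic acid or a longer chain on this aromatic carbon would leave the number equally unmoved. With only isopropyl and cyano shown here, no trend across groups at this position can be claimed.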